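The compounds below may be only part of what the source reports. "The series", "measured", "known", "first", "only" and "open" are said of these compounds alone.

Compound 1 `N=C(NCCCc1c[nH]cn1)NCCC(c1ccccc1)c1ccccn1`: 0.7
Compound 2 `N=C(NCCCc1c[nH]cn1)NCCC(c1ccc(Cl)c(Cl)c1)c1ccccn1`: 0.8
Compound 3 `N=C(NCCCc1c[nH]cn1)NCCC(c1ccccc1)c1ccc(F)cc1`: 0.7

These values come from a functional assay on muscle tissue for agonist activity at histamine H2 receptor (Cavia porcellus); a higher number here means a larger maximal response, a lower number a smaller maximal response. Compound 3 stands level with compound 1 at the digits shown, and together they are the lowest of the three numbers; the step of no change at the digits printed from compound 1 to compound 3 (within the scatter) lies within the scatter, as does a number 0.10 higher from compound 1 to compound 2 (within the scatter). Compound 4 `N=C(NCCCc1c[nH]cn1)NCCC(c1ccccc1)c1ccc(Cl)c(Cl)c1` has not yet been measured. It differs from compound 3 in one place: 3,4-dichlorophenyl in place of 4-fluorophenyl on a saturated chain carbon bound to an aromatic carbon and a saturated chain carbon. For the measured compounds named here, the only measured step that bears on this change is a number 0.10 higher from compound 1 to compound 2 (within the scatter), where 3,4-dichlorophenyl likewise entered, and that step stayed within the scatter. A similarly small step is therefore expected in this assay, upward if anything: a number 0.10 higher from compound 3 to compound 4 (within the scatter). Compound 4 is thus estimated at 0.8, within a range from 0.6 to 0.9.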

Compound 4, intrinsic activity: the largest response reached, as a fraction of the reference agonist's: 0.6
Compound 4: the middle estimate sits 0.20 above what was measured; measured number inside the range.
By their numbers in this assay, from the lowest: compounds 4, 1, 3 and 2 (each within the scatter of the next, the first and the last beyond it).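

Holding 3,4-dichlorophenyl in place, phenyl instead of pyridin-2-yl gives a number 0.20 lower from compound 2 to compound 4 (beyond the scatter) in this assay and is the first step here beyond the scatter, showing that the second group on this carbon can matter. Bringing in 3,4-dichlorophenyl gives a number 0.10 lower from compound 3 to compound 4 (within the scatter) when it replaces 4-fluorophenyl and a number 0.10 lower from compound 1 to compound 4 (within the scatter) when it replaces pyridin-2-yl, so neither of these swaps moves the response beyond the scatter.

From the compounds shown here alone, how a cyclohexyl ring or an amine on the phenyl ring would behave on this carbon remains open. Nothing measured here explains these steps.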